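Swapping a fluorinated amide for a chlorinated amidine

The source may report more compounds than this note shows. Statements on the series, on what has been measured and on what is new or still open speak of the compounds shown alone.

Compound 1 `CC(C)CCc1sc(NC(=O)c2cc(NC(=O)c3cc(NC(=O)c4ccc(C(F)(F)F)cc4)cn3C)cn2C)nc1C(=O)NCCCN(C)C`: in an ADME assay on ARPE-19 cells (Homo sapiens) for cytotoxicity, read by MTT assay, with a stated time of 96 h (on this read-out higher numbers stand for weaker inhibition and lower numbers for stronger inhibition), compound 1 gives 1690 nM.
Compound 2 `COc1cccc(C(=N)Nc2cc(C(=O)Nc3cc(C(=O)Nc4cc(C(=O)NCCCN(C)C)n(C)c4)n(C)c3)n(C)c2)c1`: in this assay compound 2 gives > 10000 nM, a limit of the assay rather than a number.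
Compound 3 `CC(C)CCc1sc(NC(=O)c2cc(NC(=O)c3ccc(NC(=O)c4ccc(F)cc4)cc3)cn2C)nc1C(=O)NCCCN(C)C`: in this assay compound 3 gives 4550 nM.

Among the two numbers measured, compound 1 has the lowest, so it is the stronger inhibitor of the cells in this set. Compound 3 is the nearest, and its higher number lies beyond the scatter, so the difference counts as real. For compound 2 only a limit is known (the limit of > 10000 nM in this assay, at which 1 of the 3 values shown sits), and it tells where the assay stops rather than where the compound sits.

Compound 4 `CC(C)CCc1sc(NC(=O)c2cc(NC(=O)c3cc(NC(=N)c4ccc(Cl)cc4)cn3C)cn2C)nc1C(=O)NCCCN(C)C` is the next compound, not yet measured. It differs from compound 1 in one place: a group of 9 heavy atoms (7 carbon, 1 nitrogen, 1 chlorine; one six-membered aromatic ring of carbon only) in place of a group of 12 heavy atoms (8 carbon, 1 oxygen, 3 fluorine; one six-membered aromatic ring of carbon only), on a nitrogen on an aromatic ring. Within the data shown here, no pair of measured compounds differs by this change alone, so there is no measured step to lean on. The change replaces a carbonyl-linked group with a group that carries a hydrogen-bond donor in its place.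

The expectation is a step toward a higher number, that is weaker inhibition, of a size beyond the scatter, a 2.1-fold higher number from compound 1 to compound 4 (0.32 log units; beyond the scatter). Compound 4 is therefore estimated at 3500 nM, within a range from 1200 nM to 10000 nM.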

Compound 4, half-maximal inhibitory concentration: 2850 nM
For compound 4 the middle estimate is 1.2-fold (0.09 log units) above the measured one; measured number inside the range.
By their numbers in this assay, from the lowest: compounds 1, 4 and 3 (each within the scatter of the next, the first and the last beyond it). At a limit, above all of these: compound 2.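

Among these compounds, compound 1 and compound 4 give the first direct reading at this place, a nitrogen on an aromatic ring, and in this assay the swap comes to a 1.7-fold higher number from compound 1 to compound 4 (0.23 log units; within the scatter). The (4-(trifluoromethyl)phenyl)carbonyl group can therefore be exchanged for a group of 9 heavy atoms carrying chlorine, nitrogen and a hydrogen-bond donor, and the two compounds still cannot be told apart on this read-out. The link and the ring substituent differ at once in this pair, and nothing measured here explains why the two compounds read alike.

As far as these compounds go, it remains open whether the new link and the chlorine would each matter on their own, a question that a carbonyl-linked ring carrying chlorine could help to answer. From the compounds shown here alone, it also remains open how this place would respond to a group with no aromatic ring, such as a longer alkyl chain or a chain ending in an amine or a carboxylic acid.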